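Ester in place of methylamide on a sesquiterpene lactone core

This account rests on a few compounds, and the source may have more. Where it says the series, first, only, none or still open, it means among the compounds named here.

Measured compounds:
compound 1 `CC(C)[C@H]1CC[C@@]2(CO2)[C@H]2C(=O)OCC(C(=O)O)=C[C@H]12` — 1340 nM
compound 2 `CNC(=O)C1=C[C@@H]2[C@@H](C(C)C)CC[C@@]3(CO3)[C@H]2C(=O)OC1` — 4150 nM
compound 3 `CC(C)[C@H]1CC[C@@](O)(CCl)[C@H]2C(=O)OCC(C(=O)O)=C[C@H]12` — 1310 nM

Three compounds have been run in a functional assay on A-375 cells (Homo sapiens) for inhibition, with a stated time of 72 h; a higher number here means a weaker inhibitor, a lower number a stronger inhibitor. Compound 2 stands at the highest number of the three; its nearest neighbour is compound 1, and compound 3 lies furthest from it. Going by the values given here, the one step that can be read off directly is a 3.1-fold higher number from compound 1 to compound 2 (0.49 log units; beyond the scatter), a modest rise on going from the free acid to the methylamide on the carbonyl carbon.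

Compound 4 `COC(=O)C1=C[C@@H]2[C@@H](C(C)C)CC[C@@]3(CO3)[C@H]2C(=O)OC1` has not yet been measured. It differs from compound 2 in one place: methoxy in place of methylamino on a carbonyl carbon. Among the compounds with values here, no measured pair exchanges an amide for an ester, so the step from compound 1 to compound 2 is the only one that bears on this change, and it bears on it only loosely, since it replaces hydroxy rather than methylamino. Within the data shown here, with that step as the sole guide, compound 4 is expected to land close to compound 2, with a 1.4-fold lower number from compound 2 to compound 4 (0.14 log units; within the scatter) falling within or just beyond the usual scatter. Compound 4 is therefore estimated at 3000 nM, with a range from 1000 nM to 9000 nM.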

Compound 4, half-maximal inhibitory concentration: 4090 nM
Beside the measured number, compound 4's estimate is 1.4-fold (0.13 log units) below it; measured number inside the range.
By their numbers in this assay, from the lowest: compounds 3 and 1 (each within the scatter of the next); then compounds 4 and 2 (each within the scatter of the next).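

In this assay, methoxy and methylamino on this carbonyl carbon cannot be told apart, with a 1.0-fold lower number from compound 2 to compound 4 (0.01 log units; within the scatter), so the hydrogen-bond donor of methylamino makes no difference here beyond the scatter. Methylating the free acid to the ester gives a 3.1-fold higher number from compound 1 to compound 4 (0.48 log units; beyond the scatter), a step of much the same size as a 3.1-fold higher number from compound 1 to compound 2 (0.49 log units; beyond the scatter), so on the core of compound 1 both replacements of the hydroxy go the same way. No measurement at hand offers an explanation for this result.

As far as these compounds go, it remains open whether a primary amide, a dimethylamide or an ethyl ester on this carbonyl carbon would read like compound 2 and compound 4 or like compound 1. Also open, from the compounds shown here alone, is how the methoxy group would read on the core of compound 3.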